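A few compounds are considered here, and "the series" means these few. Any claim that something is new, unique, unknown or untested is made for them only; others in the source may bear on it.

Measured compounds in a functional assay on 1321-N1 cells for agonist activity at P2Y purinoceptor 4 (Homo sapiens), read by scintillation counting and inositol phosphate accumulation; a higher number here means that more compound is needed for the effect, a lower number that less compound is needed:
- compound 1 `O=c1[nH]/c(=N\OCCCCc2ccccc2)ccn1[C@@H]1O[C@H](COP(=O)(O)OP(=O)(O)OP(=O)(O)O)[C@@H](O)[C@H]1O`: 54 nM
- compound 2 `O=c1[nH]/c(=N\OCCOc2ccccc2)ccn1[C@@H]1O[C@H](COP(=O)(O)OP(=O)(O)OP(=O)(O)O)[C@@H](O)[C@H]1O`: 430 nM
- compound 3 `O=c1[nH]/c(=N\OCCCc2ccc(I)cc2)ccn1[C@@H]1O[C@H](COP(=O)(O)OP(=O)(O)OP(=O)(O)O)[C@@H](O)[C@H]1O`: 91 nM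

Compound 3 holds the second highest number of the three in this assay; its nearest neighbour is compound 1, with a 1.7-fold higher number from compound 1 to compound 3 (0.23 log units; within the scatter), and its furthest is compound 2, with a 4.7-fold lower number from compound 2 to compound 3 (0.67 log units; beyond the scatter).

Compound 4 `O=c1[nH]/c(=N\OCCCc2cccnc2)ccn1[C@@H]1O[C@H](COP(=O)(O)OP(=O)(O)OP(=O)(O)O)[C@@H](O)[C@H]1O` differs from compound 3 by pyridin-3-yl in place of 4-iodophenyl on a saturated chain carbon, three bonds along the chain from an oxygen. For the measured compounds named here, no measured step swaps one aryl group for another at this position, so the nearest guide is the change from compound 1 to compound 3 in this assay, a benzyl-to-4-iodophenyl exchange at the same place: a 1.7-fold higher number from compound 1 to compound 3 (0.23 log units; within the scatter). The larger step of a 4.7-fold lower number from compound 2 to compound 3 (0.67 log units; beyond the scatter) involves the chain itself and bears less directly on the ring exchange. The iodine leaves and a ring nitrogen enters, which takes compound 4 outside what the measured set covers.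

Because a 1.7-fold higher number from compound 1 to compound 3 (0.23 log units; within the scatter) stayed within the scatter, compound 4 is expected to give 150 nM in this assay, a step of a 1.6-fold higher number from compound 3 to compound 4 (0.22 log units; within the scatter), with a range from 45 nM to 500 nM.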

Compound 4, half-maximal effective concentration: 300 nM
For compound 4 the middle estimate is 2.0-fold (0.30 log units) below the measured one; the range from low to high includes it.
By their numbers in this assay, from the lowest: compounds 1 and 3 (each within the scatter of the next); then compounds 4 and 2 (each within the scatter of the next).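

In this assay the exchange of the ring gives a 3.3-fold higher number from compound 3 to compound 4 (0.52 log units; beyond the scatter) and so shows that this position does not tolerate every aryl group, which the benzyl to 4-iodophenyl step within the scatter gave no sign of. Against the compound with the longer chain, the same ring gives a 5.6-fold higher number from compound 1 to compound 4 (0.74 log units; beyond the scatter) and so stays apart from it, while a 1.4-fold lower number from compound 2 to compound 4 (0.16 log units; within the scatter) leaves compound 4 level with the phenoxy compound. Nothing at hand explains this shift.

Since the iodine leaves and the ring nitrogen enters in one step, plain phenyl at this place would be needed to separate the two changes. Pyridin-2-yl or pyridin-4-yl, or a carboxylic acid or an amine on the ring, remain open here.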